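The source may hold more compounds than are shown below. What is called first, only, known or untested is meant among the compounds shown, and "the series" means these compounds.

In a functional assay on SNB-19 cells (Homo sapiens) for inhibition, with a stated time of 48 h (on this read-out higher numbers stand for weaker inhibition of growth and lower numbers for stronger inhibition of growth), compound 1 `COc1c(C(=O)/C=C/c2ccc(Cl)cc2)c(O)c(Br)c2occc12` gives 8240 nM, while compound 2 `C=CCc1c(O)c(C(=O)/C=C/c2ccccc2)c(OC)c2ccoc12` gives 2850 nM, the lower of the two numbers and a gap beyond the scatter. Compound 3 `C=CCc1c(O)c(C(=O)/C=C/c2ccc(Cl)cc2)c(OC)c2ccoc12` differs from compound 2 in one place, chloro in place of hydrogen on an aromatic carbon, para to a large group: chloro in place of hydrogen on an aromatic carbon. Going by the values given here, no measured pair shows this change on its own, so the expectation is no step beyond the scatter, in either direction. The step expected is a 1.1-fold lower number from compound 2 to compound 3 (0.04 log units; within the scatter). The estimated value for compound 3 is 2600 nM, within a range from 1100 nM to 6500 nM.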

Compound 3, concentration for 50% growth inhibition: 2850 nM
Estimate against measurement, compound 3: 1.1-fold (0.04 log units) below; the range from low to high includes it.
By their numbers in this assay, from the lowest: compounds 2 and 3 (each within the scatter of the next); then compound 1.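

On this assay, chloro in place of hydrogen on an aromatic carbon, para to a large group, gives no change at the digits printed from compound 2 to compound 3 (within the scatter), so phenyl and 4-chlorophenyl are not told apart at this position. With 4-chlorophenyl in both compounds, allyl in place of bromo on an aromatic carbon gives a 2.9-fold lower number from compound 1 to compound 3 (0.46 log units; beyond the scatter), and of these two changes only this one goes beyond the scatter. Nothing at hand explains either result. Only hydrogen and chloro are shown at this para place, so an amine or a carboxylic acid there remains open. Going by these compounds, whether a longer chain in place of allyl would hold or shift the number also remains open.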